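Hydroxy for 2-cyanoethyl at the limit of the assay

The source may hold more compounds than are shown below. What is called first, only, known or untested is meant among the compounds shown, and "the series" means these compounds.

Compound 1 `Cc1cc(C)c(S(=O)(=O)N2CCC(N3CCCCCC3)CC2)c(C)c1` and compound 2 `Cc1cc(C)c(S(=O)(=O)N2CCC(N3CCC(CCC#N)CC3)CC2)c(C)c1` share a core. In an ADME assay on HCT-116 cells (Homo sapiens) for cytotoxicity, read by CellTiter-Glo, with a stated time of 72 h (on this read-out higher numbers stand for weaker inhibition and lower numbers for stronger inhibition), compound 1 gives > 5000 nM as a limit and not a number. Compound 2 likewise gives > 5000 nM as a limit, so neither compound yet has a number (the limit of > 5000 nM in this assay, at which 2 of the 2 values shown sit). Compound 3 `Cc1cc(C)c(S(=O)(=O)N2CCC(N3CCC(O)CC3)CC2)c(C)c1` carries hydroxy in place of 2-cyanoethyl on a saturated ring carbon. In this assay the expected result is a step that the limit leaves unreadable from compound 2 to compound 3 with no change beyond the scatter and no direction. This expectation rests on compound 2 and its limit of > 5000 nM alone. For compound 3 the estimate is 7000 nM (expected range 3000 nM to 15000 nM).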

Compound 3, half-maximal inhibitory concentration: > 5000 nM
Compound 3 ended at the assay's limit; the forecaster's own chance of this, stated with the estimate: 80%; the middle value does not contradict the limit.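

Compound 1, compound 2 and compound 3 all stand at a limit and not a number in this assay, so no step between them can be read: the limit of > 5000 nM in this assay, at which 3 of the 3 values shown sit.

The compounds shown leave open which change to the shared core, if any, would bring a number within reach of this assay.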